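Shifting a halogen around the phenyl ring of compound 3

A few compounds are considered here, and "the series" means these few. Any claim that something is new, unique, unknown or untested is made for them only; others in the source may bear on it.

Of the compounds shown here, three sharing one core have been measured in an assay on isolated protein for inhibition of Indoleamine 2,3-dioxygenase 1 (Homo sapiens), read by spectrophotometry, with a stated time of 1 h; on this read-out lower numbers stand for stronger inhibition and higher numbers for weaker inhibition. Compound 1 `O=[N+]([O-])c1ccc(N/C(=N\O)c2ccccc2F)c2nonc12` gives 63 nM, compound 2 `O=[N+]([O-])c1ccc(N/C(=N\O)c2ccccc2Cl)c2nonc12` gives 135 nM, and compound 3 `O=[N+]([O-])c1ccc(N/C(=N\O)c2cccc(Cl)c2)c2nonc12` gives 184 nM. Compound 3 stands at the highest number of the three: the gap to compound 2 is within the scatter, while the gap to compound 1 is beyond it. The next compound, compound 4 `O=[N+]([O-])c1ccc(N/C(=N\O)c2ccc(F)cc2)c2nonc12`, differs from compound 3 by 4-fluorophenyl in place of 3-chlorophenyl on a carbon with a double bond to nitrogen. Going by the values given here, two measured steps bear on this. Swapping fluoro for chloro on the ring gave a 2.1-fold higher number from compound 1 to compound 2 (0.33 log units; beyond the scatter), and moving the chloro from one ring position to another gave a 1.4-fold higher number from compound 2 to compound 3 (0.13 log units; within the scatter). Compound 4 combines both kinds of change, bringing back fluoro at a third position not yet sampled. Since compound 1 carries fluoro and reads 63 nM, a modestly lower number than compound 3 is expected, though the new position leaves the size uncertain. For compound 4 the step is estimated as a 1.4-fold lower number from compound 3 to compound 4 (0.15 log units; within the scatter), and its value in this assay is expected to be 130 nM, within a range of 45 nM to 400 nM.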

Compound 4, half-maximal inhibitory concentration: 100 nM
Compound 4: the middle estimate sits 1.3-fold (0.11 log units) above what was measured; low and high end bracket the measured number.
By their numbers in this assay, from the lowest: compounds 1, 4, 2 and 3 (each within the scatter of the next, the first and the last beyond it).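

In this assay, 4-fluorophenyl in place of 3-chlorophenyl gives a 1.8-fold lower number from compound 3 to compound 4 (0.26 log units; within the scatter), and 4-fluorophenyl in place of 2-chlorophenyl gives a 1.4-fold lower number from compound 2 to compound 4 (0.13 log units; within the scatter), so compound 4 cannot be told apart from either chlorophenyl compound. Moving the fluoro on the phenyl ring gives a 1.6-fold higher number from compound 1 to compound 4 (0.20 log units; within the scatter), which shows that this change of fluoro position, like the earlier change of chloro position, stays within the scatter, and compound 4 thus lies within the scatter of all three earlier compounds, even though compound 1 is separated from compound 3 by a 2.9-fold higher number from compound 1 to compound 3 (0.47 log units; beyond the scatter). Nothing available explains how these groups on the carbon with a double bond to nitrogen relate to the read-out.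

The compounds shown leave open how 3-fluorophenyl and 4-chlorophenyl would read, which would show whether fluoro and chloro track each other at each ring position. They also leave open whether this place accepts anything other than a single halogen, such as an unsubstituted phenyl, a methoxy group, a nitrile or an amine on the ring.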